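A Small Methyl Change on a Well-Tolerated Core

The compounds below may be only part of what the source reports. "The series", "measured", "known", "first", "only" and "open" are said of these compounds alone.

Compound 1, with the structure `O=c1ccn(COC(CO)CO)c(=O)[nH]1`, was tested in a functional assay on HepG2 cells (Homo sapiens) for cytotoxicity; a lower number here means that less compound is tolerated, a higher number that more compound is tolerated. In this assay compound 1 reaches only a limit, > 462000 nM, so no exact number is known for it. Among the measured compounds shown here, the one other measured compound is compound 2, `O=c1[nH]c(=O)n(COC(CO)CO)cc1CCO`, which carries a 2-hydroxyethyl in place of hydrogen on an aromatic carbon of the shared core. For compound 2 this assay likewise gives only a limit, > 384000 nM. The step that the two limits leave unreadable from compound 1 to compound 2 cannot be sized, because the limit of > 384000 nM in this assay, at which 1 of the 2 values shown sits, and the limit of > 462000 nM in this assay, at which 1 of the 2 values shown sits, are both limits rather than numbers.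

Compound 3, `Cc1cc(=O)[nH]c(=O)n1COC(CO)CO`, differs from compound 1 by methyl in place of hydrogen on an aromatic carbon. For the measured compounds named here, no measured step gives a readable size or direction, so the change is expected to leave tolerance where it stands, an estimated step that the limit leaves unreadable from compound 1 to compound 3. Compound 3 is therefore expected to give 500000 nM, with a range from 200000 nM to 2000000 nM.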

Compound 3, half-maximal cytotoxic concentration: > 434000 nM
Compound 3 was reported as a limit (the forecaster's own chance of this, stated with the estimate: 85%); the middle value lies beyond the limit too.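

Compound 1 and compound 3 both give only limits in this assay, so the methyl step between them cannot be read. The compounds shown leave open whether methyl or 2-hydroxyethyl on the shared core changes tolerance at all, and what concentration harms the cells.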